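The compounds below may be only part of what the source reports. "The series", "measured", "known", "first", "only" and "open" are said of these compounds alone.

Compound 1 `CCN(Cc1ccccc1)C(=O)C1CCN(S(=O)(=O)c2ccc(C)s2)CC1` gives 64% in a functional assay on CHO cells for positive allosteric modulation of muscarinic acetylcholine receptor M5 (Homo sapiens), read by calcium flux; a higher number here means a larger maximal response, a lower number a smaller maximal response.
Compound 2 `CCN(Cc1ccccc1)C(=O)C1CCN(S(=O)(=O)c2c(C)noc2C)CC1` gives "not determined" (no result reported) in this assay.
Compound 3 `CCN(Cc1cccc(Cl)c1)C(=O)C1CCN(S(=O)(=O)c2ccc3cn[nH]c3c2)CC1` gives 77% in this assay.

All three share one core and differ in the groups at its two ends. In this assay compound 1 gives 64%, while compound 3 gives 77%, the higher of the two numbers by a gap beyond the usual scatter. Compound 2 carries no number at all, its entry being "not determined" (no result reported).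

Compound 4 `CCN(Cc1cccc(C(F)(F)F)c1)C(=O)C1CCN(S(=O)(=O)c2ccc3cn[nH]c3c2)CC1` differs from compound 3 in one place: trifluoromethyl in place of chloro on an aromatic carbon. Going by the values given here, no pair of measured compounds shows this change, so the expectation leans on compound 3 alone. The change is expected to move the result only a little, if at all, with the expected step of a number 2 percentage points lower from compound 3 to compound 4 (within the scatter) staying within the scatter. Compound 4 is therefore estimated to give about 75%, most likely between 55% and 95%.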

Compound 4, largest response reached (reported as percent of maximum), in percent of the reference or control that the assay uses: 59%
Compound 4: the middle estimate sits 16 percentage points above what was measured, within the range that was stated.
By their numbers in this assay, from the lowest: compounds 4 and 1 (each within the scatter of the next); then compound 3.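

In this assay, trifluoromethyl in place of chloro on this aromatic carbon gives a number 18 percentage points lower from compound 3 to compound 4 (beyond the scatter). Going by these compounds alone, compounds 3 and 4 are the first pair here to differ in one place, so this is the first direct sign that the group at this position can change the maximal response. Nothing at hand explains the step.

As far as these compounds go, it remains open how a methoxy group or a nitrile at the same place would compare with chloro and trifluoromethyl. From the compounds shown here alone, it is also open whether the same exchange would give a similar step with a different group on the sulfonyl end.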